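Thienylmethyl amides on the shared core: a pyrazinyl variant

This account rests on a few compounds, and the source may have more. Where it says the series, first, only, none or still open, it means among the compounds named here.

Measured so far:
compound 1, `Cc1ccc(OCC(=O)N(Cc2cccs2)CC(C)C)cc1`, 900 nM
compound 2, `CCN(Cc1cccs1)C(=O)C[C@H](O)c1ccccc1`, 52000 nM

Both values come from an assay on HEK293 cells for agonist activity at transient receptor potential cation channel subfamily M member 8 (Homo sapiens), read by fluorescence and calcium flux, with a stated time of 15 min; a higher number here means that more compound is needed for the effect, a lower number that less compound is needed. Compound 1 holds the lower of the two numbers in this assay; compound 2 sits at a higher number, and the gap between the two lies well beyond the scatter. The two differ in several places at once, so no single change can be tied to that gap; only the two values themselves are informative.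

Compound 3, `Cc1ccc(OCC(=O)N(Cc2cccs2)c2cnccn2)cc1`, is the next variant and has not yet been run in this assay. It departs from compound 1 in one place: pyrazin-2-yl in place of isobutyl on an amide-type nitrogen. Pyrazin-2-yl in place of isobutyl on an amide-type nitrogen, whose other neighbours are the carbonyl carbon and a saturated chain carbon, is the whole of the change.

For the measured compounds named here, no step between measured compounds isolates this kind of exchange, so the expectation rests on compound 1 alone. A moderate move toward a higher number is expected, a 3.3-fold higher number from compound 1 to compound 3 (0.52 log units; beyond the scatter), though a result within the scatter would not be surprising. For compound 3 the estimate in this assay is 3000 nM, with a range from 600 nM to 15000 nM.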

Compound 3, half-maximal effective concentration: 1240 nM
Compound 3: middle estimate off by 2.4-fold (0.38 log units), on the high side, and the stated range covers the measured number.
By their numbers in this assay, from the lowest: compounds 1 and 3 (each within the scatter of the next); then compound 2.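

In this assay, for the compounds shown here, pyrazin-2-yl in place of isobutyl on the amide-type nitrogen gives a 1.4-fold higher number from compound 1 to compound 3 (0.14 log units; within the scatter), the first step that isolates a single change. At this position, therefore, an open chain with no ring and a six-membered aromatic ring with hetero atoms give numbers that cannot be told apart, even though the two groups share little beyond the absence of hydrogen-bond donors and of net charge. No measurement available here bears on the reason for this outcome.

The compounds shown leave open whether the ring nitrogens of pyrazin-2-yl matter at all, a question that phenyl or pyridin-2-yl on the same nitrogen would address, and how far the position extends to groups of other kinds, such as a carboxylic acid or an amine on a longer chain. Going by these compounds alone, they also leave open whether the same exchange behaves alike when the thiophen-2-ylmethyl group or the 4-methylphenoxy group of the shared core is replaced, since only this one step has been read.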